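Working notes: from bromo to hydroxy in the series

A few compounds are considered here, and "the series" means these few. Any claim that something is new, unique, unknown or untested is made for them only; others in the source may bear on it.

Measured in a functional assay on HT-29 cells (Homo sapiens); a higher number here means a weaker inhibitor of growth, a lower number a stronger inhibitor of growth
- compound 1 `O=S(=O)(/C=C/c1ccc(Cl)c(Cl)c1)Cc1ccc(Nc2ncnc3ccc(Br)cc23)cc1` gives 27000 nM
- compound 2 `O=S(=O)(/C=C/c1ccc(Br)cc1)Cc1ccc(Nc2ncnc3ccc(Br)cc23)cc1` gives 10000 nM

Within the data shown here, of the two measured compounds, compound 2 has the lower number (10000 nM), and compound 1 is its only neighbour. The next structure is compound 3 (`O=S(=O)(/C=C/c1ccc(O)cc1)Cc1ccc(Nc2ncnc3ccc(Br)cc23)cc1`), which has hydroxy in place of bromo on an aromatic carbon, para to a large group (hydroxy in place of bromo on an aromatic carbon).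

Among the measured compounds shown here, one measured step bears on this change: 4-bromophenyl in place of 3,4-dichlorophenyl (a 2.7-fold lower number from compound 1 to compound 2 (0.43 log units; beyond the scatter)). It is modest but beyond the scatter, and it involves the same terminal aromatic ring. For the measured compounds named here, no measured compound carries hydroxy, so the data give no firm direction for the new exchange. In this assay a step no larger than that modest one is expected, quite possibly none beyond the scatter, with a slight lean toward a higher number.

The expected change is a 1.3-fold higher number from compound 2 to compound 3 (0.11 log units; within the scatter) in this estimate. For compound 3 the estimated value is 13000 nM (expected range 4000 nM to 35000 nM).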

Compound 3, concentration for 50% growth inhibition: 9000 nM
Compound 3: middle estimate off by 1.4-fold (0.16 log units), on the high side, within the range that was stated.
By their numbers in this assay, from the lowest: compounds 3 and 2 (each within the scatter of the next); then compound 1.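

In this assay, among these compounds, the exchange at the aromatic carbon para to a large group gives a 1.1-fold lower number from compound 2 to compound 3 (0.05 log units; within the scatter), so this position carries hydroxy, with its hydrogen-bond donor and acceptor, and the number stays within the scatter of the bromo compound; the earlier compounds held only halogens on this ring and could not show this. Against the 3,4-dichlorophenyl compound, the 4-hydroxyphenyl compound gives a 3.0-fold lower number from compound 1 to compound 3 (0.48 log units; beyond the scatter), a modest step beyond the scatter in the same direction as the one seen for 4-bromophenyl, so the separation of compound 1 from the others does not depend on a halogen remaining at this position. No accompanying measurement offers an explanation for this result.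

Open, from the compounds shown here alone, is whether an amine, a carboxylic acid or a methoxy group on the same aromatic carbon would also stay within the scatter of compound 3, or whether the tolerance seen here is limited to bromo and hydroxy. Also open is whether compound 3, at 9000 nM, marks the best level reachable through this ring, or whether some other group there gives a step larger than the modest ones shown.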